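The compounds below may be only part of what the source reports. "The series", "measured", "known", "first", "only" and "open" are said of these compounds alone.

Measured so far in an ADME assay on a cell-free system (plasma, Mus musculus) for metabolic stability, read by LC-MS, tested at 2 uM (on this read-out higher numbers stand for a longer-lived compound and lower numbers for a shorter-lived compound), for three compounds
Compound 1 `CC(C)CNC(=O)n1c(=O)oc2ccc(C3CCN(C)CC3)cc21` gives 0.5 h
Compound 2 `CC(C)CN1CCC(c2ccc3c(c2)oc(=O)n3C(=O)NCCCCc2ccccc2)CC1` gives 1 h
Compound 3 `CC(C)CNC(=O)n1c(=O)oc2cc(C3CCCN(C)C3)ccc21` gives 0.833 h

Compound 2 gives 1 h here, and the values of the other two compounds lie within the usual scatter of it, so the three cannot be told apart on this read-out. Compound 4 `CN1CCC(c2ccc3c(c2)oc(=O)n3C(=O)NCCCCc2ccccc2)CC1` is compound 2 with a single change (hydrogen in place of isopropyl on a saturated chain carbon bound to an amine nitrogen in a ring): hydrogen in place of isopropyl on a saturated chain carbon bound to an amine nitrogen in a ring, which turns isobutyl into methyl. For the measured compounds named here, no measured pair shows this change alone. Compound 1 also carries 1-methylpiperidin-4-yl, though it differs from compound 2 elsewhere, and compound 1 at 0.5 h sits within the scatter of compound 2. In this assay no step beyond the scatter is therefore expected, only perhaps a slight drop. The expected step of a 1.3-fold lower number from compound 2 to compound 4 (0.10 log units; within the scatter) is small. For compound 4 the estimated half-life is 0.8 h with an expected range from 0.4 h to 1.6 h in this test.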

Compound 4, half-life: 0.833 h
Beside the measured number, compound 4's estimate is 1.0-fold (0.02 log units) below it; low and high end bracket the measured number.
By their numbers in this assay, from the lowest: compounds 1, 3, 4 and 2 (each within the scatter of the next).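

Going from 1-isobutylpiperidin-4-yl to 1-methylpiperidin-4-yl gives, in this assay, a 1.2-fold lower number from compound 2 to compound 4 (0.08 log units; within the scatter), and this is the first pair in which this change stands alone. The earlier compounds shown here differed in more than one place, whereas this pair shows that, with the rest of the molecule held fixed, removing the isopropyl part of isobutyl produces no step that this read-out can separate from repeat scatter. No measurement here offers a reason for this result.

As far as these compounds go, it remains open whether a bare hydrogen or a benzyl group on the amine nitrogen in the ring would give a step beyond the scatter. From the compounds shown here alone, it also remains open whether isobutyl and methyl would match as closely on the core of compound 1, which differs from compound 2 elsewhere.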